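Quinolin-6-yl in Place of Pyridin-3-yl: Expecting Compound 4

A few compounds are considered here, and "the series" means these few. Any claim that something is new, unique, unknown or untested is made for them only; others in the source may bear on it.

Measured so far, each in a functional assay on Caco-2 cells (Homo sapiens) for cytotoxicity, read by MTT assay, with a stated time of 48 h; on this read-out higher numbers stand for weaker inhibition and lower numbers for stronger inhibition:
Compound 1, `O=C(O[C@H]1C[C@H](n2cc(F)c(=O)[nH]c2=O)O[C@@H]1COP(=O)(O)Oc1cccnc1)c1ccccc1`, gives 2500 nM.
Compound 2, `O=C(O[C@H]1C[C@H](n2cc(F)c(=O)[nH]c2=O)O[C@@H]1COP(=O)(O)Oc1ccc2ncccc2c1)c1ccccc1`, gives 2460 nM.
Compound 3, `O=c1[nH]c(=O)n([C@H]2C[C@H](O)[C@@H](COP(=O)(O)Oc3cccnc3)O2)cc1F`, gives 3390 nM.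

Compound 2 differs from compound 1 by one change, (quinolin-6-yl in place of pyridin-3-yl on an oxygen), and the result was a 1.0-fold lower number from compound 1 to compound 2 (0.01 log units; within the scatter). Compound 3 differs from compound 1 at its core, (hydrogen in place of benzoyl on an oxygen on a saturated carbon), with a 1.4-fold higher number from compound 1 to compound 3 (0.13 log units; within the scatter).

Compound 4, `O=c1[nH]c(=O)n([C@H]2C[C@H](O)[C@@H](COP(=O)(O)Oc3ccc4ncccc4c3)O2)cc1F`, is not yet measured. It differs from compound 3 by quinolin-6-yl in place of pyridin-3-yl on an oxygen, the same change as in the first pair, at the same place.

For the measured compounds named here, since the only such step seen, a 1.0-fold lower number from compound 1 to compound 2 (0.01 log units; within the scatter), left the number essentially unchanged, the step to compound 4 is expected to be a 1.0-fold lower number from compound 3 to compound 4 (0.01 log units; within the scatter) in this assay. Compound 4 is therefore estimated at 3300 nM, expected to fall between 1600 nM and 7000 nM.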

Compound 4, half-maximal inhibitory concentration: 1400 nM
Beside the measured number, compound 4's estimate is 2.4-fold (0.37 log units) above it; the measured number lies below the stated range.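

In this assay, quinolin-6-yl in place of pyridin-3-yl gives a 2.4-fold lower number from compound 3 to compound 4 (0.38 log units; beyond the scatter), yet the two steps for this change cannot be told apart: the same change on two cores in this assay, a 1.0-fold lower number (0.01 log units; within the scatter) from compound 1 to compound 2 and a 2.4-fold lower number (0.38 log units; beyond the scatter) from compound 3 to compound 4, 2.4-fold (0.38 log units) apart, within the scatter of two such steps. Hydrogen in place of benzoyl gives a 1.8-fold lower number from compound 2 to compound 4 (0.24 log units; within the scatter), and this step also cannot be told apart from its earlier counterpart: the same change on two cores in this assay, a 1.4-fold higher number (0.13 log units; within the scatter) from compound 1 to compound 3 and a 1.8-fold lower number (0.24 log units; within the scatter) from compound 2 to compound 4, 2.4-fold (0.38 log units) apart, within the scatter of two such steps. So the larger step on the core without benzoyl does not show that the effect of the change depends on the core, nor do two pairs prove that it carries over unchanged, even between these two cores.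

The compounds shown leave open how a plain phenyl would behave in place of quinolin-6-yl. They also leave open the effect of acetyl in place of benzoyl in this assay.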